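Swapping halogens on the benzyl sulfide of a shared core

This account rests on a few compounds, and the source may have more. Where it says the series, first, only, none or still open, it means among the compounds named here.

Measured so far:
compound 1, `Cn1cc(SCc2nnc(SCc3ccccc3C#N)n2-c2c(Cl)cccc2Cl)c2ccccc21` — 78600 nM
compound 2, `Cn1cc(SCc2nnc(SCc3cccc(Cl)c3Cl)n2-c2c(Cl)cccc2Cl)c2ccccc21` — > 100000 nM

In a toxicity assay on HEK-293T cells (Homo sapiens) for cytotoxicity, read by CCK-8 assay, with a stated time of 48 h (a higher number here means that more compound is tolerated, a lower number that less compound is tolerated), compound 1 gives 78600 nM. For compound 2 the result is a limit of the assay, > 100000 nM, so only a range is known for it. The step of an at least 1.2-fold higher number from compound 1 to compound 2 (0.10 log units; that floor lies within the scatter) is read against (the limit of > 100000 nM in this assay, at which 1 of the 2 values shown sits). Compound 2 therefore stands at the tolerated end of the two numbers shown, with no exact value.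

Compound 3, `Cn1cc(SCc2nnc(SCc3c(F)cccc3Cl)n2-c2c(Cl)cccc2Cl)c2ccccc21`, has not been measured in this assay. It differs from compound 2 by 2-chloro-6-fluorophenyl in place of 2,3-dichlorophenyl on a saturated chain carbon bound to a sulfur. Within the data shown here, the one measured step, which also changed the group on this saturated chain carbon bound to a sulfur, stayed within the scatter, and both measured compounds sit near or beyond the limit. No shift beyond the scatter is expected: the step of a number no higher from compound 2 to compound 3 (the limit leaves the size open) is estimated as flat. Compound 3 is expected to give about 100000 nM, between 50000 nM and 250000 nM.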

Compound 3, half-maximal cytotoxic concentration: > 100000 nM
Compound 3: only a limit was reported (the forecaster's own chance of this, stated with the estimate: 55%); the middle value sits exactly at the limit.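

In this assay compound 3 gives > 100000 nM and this is a limit of the assay, so a second halogenated ring on the saturated chain carbon bound to a sulfur stops at the same limit as the first. Placing 2-chloro-6-fluorophenyl where 2-cyanophenyl stood gives an at least 1.2-fold higher number from compound 1 to compound 3 (0.10 log units; that floor lies within the scatter) and so repeats what the 2,3-dichlorophenyl group showed, with no step shown beyond the scatter. The step between compound 2 and compound 3 cannot be read because both values stop at the same limit: the limit of > 100000 nM in this assay, at which 2 of the 3 values shown sit.

Going by these compounds, how far either halogenated compound lies beyond that limit stays open, so the two rings cannot be ranked. Also open, on these data alone, is whether an amine or a carboxylic acid on this benzyl position would give a readable number.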